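The source may hold more compounds than are shown below. What is called first, only, known or untested is meant among the compounds shown, and "the series" means these compounds.

In a functional assay on DU-145 cells (Homo sapiens), read by sulforhodamine B assay, with a stated time of 5 days (a lower number here means a stronger inhibitor of growth, a higher number a weaker inhibitor of growth), compound 1 `OC[C@H]1O[C@@H](n2cc(F)c3c(-c4ccccc4)ncnc32)[C@H](O)[C@@H]1O` gives 580 nM, compound 2 `OC[C@H]1O[C@@H](n2cc(F)c3c(-c4nccs4)ncnc32)[C@H](O)[C@@H]1O` gives 24 nM and compound 3 `OC[C@H]1O[C@@H](n2cc(Cl)c3c(-c4ccccc4)ncnc32)[C@H](O)[C@@H]1O` gives 140 nM, which places compound 3 in the middle of the three. Compound 4 `OC[C@H]1O[C@@H](n2cc(Cl)c3c(-c4ccsc4)ncnc32)[C@H](O)[C@@H]1O` keeps the chloro group of compound 3 but has thiophen-3-yl in place of phenyl on an aromatic carbon. The closest measured precedent is the exchange of phenyl for 1,3-thiazol-2-yl, a large step of a 24-fold lower number from compound 1 to compound 2 (1.38 log units; beyond the scatter), although it was measured with fluoro rather than chloro. The modest exchange of fluoro for chloro, a 4.1-fold lower number from compound 1 to compound 3 (0.62 log units; beyond the scatter), is already contained in compound 3. Within the data shown here, no thiophen-3-yl compound has been measured, so a smaller step in the same direction is expected in this assay. The estimated change is a 4.0-fold lower number from compound 3 to compound 4 (0.60 log units; beyond the scatter). For compound 4, the expected value is 35 nM, within an estimated range of 9 nM to 120 nM.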

Compound 4, concentration for 50% growth inhibition: 18 nM
Compound 4: middle estimate off by 1.9-fold (0.29 log units), on the high side, within the range that was stated.
By their numbers in this assay, from the lowest: compounds 4 and 2 (each within the scatter of the next); then compound 3; then compound 1.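

With the chloro group held fixed, thiophen-3-yl in place of phenyl gives a 7.8-fold lower number from compound 3 to compound 4 (0.89 log units; beyond the scatter) in this assay, so a lower number on leaving phenyl is now seen with chloro as well as with fluoro. It also shows that the five-membered aromatic ring carrying a single hetero atom, sulfur, is enough for a step beyond the scatter at this position. No evidence on why the number falls is available. Still open, from the compounds shown here alone, are thiophen-3-yl paired with fluoro and 1,3-thiazol-2-yl paired with chloro. Also open, going by these compounds, is how an amine at this aromatic carbon would compare with these rings.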